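Pyridin-4-yl in place of phenyl: expectation for compound 4

The source may hold more compounds than are shown below. What is called first, only, known or untested is meant among the compounds shown, and "the series" means these compounds.

Compound 1 `O=S(=O)(Nc1cc(-c2cnc3[nH]ncc3c2)cnc1Cl)c1ccccc1`: 7400 nM in a functional assay on MCF7 cells (Homo sapiens) for inhibition, read by sulforhodamine B assay, with a stated time of 72 h; a lower number here means a stronger inhibitor of growth, a higher number a weaker inhibitor of growth
Compound 2 `O=S(=O)(Nc1cc(-c2cnc3[nH]nc(-c4ccccc4)c3c2)cnc1Cl)c1ccccc1`: 7370 nM
Compound 3 `O=S(=O)(Nc1cc(-c2cnc3[nH]cc(-c4ccccc4)c3c2)cnc1Cl)c1ccccc1`: > 10000 nM, an assay limit rather than a number

Among the two numbers, compound 2 gives the lowest, with compound 1 within the scatter of it. For compound 3 only the limit of > 10000 nM in this assay, at which 1 of the 3 values shown sits, is known. Going by the values given here, the one measured step, a 1.0-fold lower number from compound 1 to compound 2 (0.00 log units; within the scatter), adds phenyl to the core of compound 1.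

Compound 4 `O=S(=O)(Nc1cc(-c2cnc3[nH]nc(-c4ccncc4)c3c2)cnc1Cl)c1ccccc1` changes compound 2 by pyridin-4-yl in place of phenyl on an aromatic carbon. Among the compounds with values here, no measured step exchanges phenyl for pyridin-4-yl, so only the flat step from compound 1 to compound 2 bears on it, and no step beyond the scatter is expected in this assay. Compound 4 is estimated at 7000 nM, between 3000 nM and 15000 nM, which means an expected step of a 1.1-fold lower number from compound 2 to compound 4 (0.02 log units; within the scatter).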

Compound 4, concentration for 50% growth inhibition: 690 nM
Estimate against measurement, compound 4: 10-fold (1.01 log units) above; measured number below the stated range.
By their numbers in this assay, from the lowest: compound 4; then compounds 2 and 1 (each within the scatter of the next). At a limit, above all of these: compound 3.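

In this assay, the group on this aromatic carbon of the shared core now matters: pyridin-4-yl in place of phenyl gives an 11-fold lower number from compound 2 to compound 4 (1.03 log units; beyond the scatter), and pyridin-4-yl in place of hydrogen gives an 11-fold lower number from compound 1 to compound 4 (1.03 log units; beyond the scatter), whereas phenyl in place of hydrogen gave no step beyond the scatter. The gain therefore follows the exchange of a single ring carbon for nitrogen, not the mere presence of a six-membered aromatic ring at this place. No measurement shown gives a cause for this step.

Going by these compounds, whether pyridin-3-yl or pyridin-2-yl would carry the same step stays open. So does the effect of an amine or a carboxylic acid on this ring.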